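Swapping methylamino for methyl on a poorly soluble core

A few compounds are considered here, and "the series" means these few. Any claim that something is new, unique, unknown or untested is made for them only; others in the source may bear on it.

Measured so far:
compound 1, `CC(C)n1nc(-c2ccc3oc(N)nc3c2)c2c(Br)nc(N)nc21`: 4000 nM
compound 2, `CC(C)n1nc(-c2ccc3oc(N)nc3c2)c2cnc(N)nc21`: 1600 nM
compound 3, `CNc1nc2c(c(-c3ccc4oc(N)nc4c3)nn2C(C)C)c(=O)[nH]1`: < 1000 nM

In a physicochemical assay for solubility, read by HPLC, in phosphate buffer, measured as kinetic solubility, with a stated time of 24 h, at 20 degrees C, at pH 7.4, tested at 100 uM (a higher number here means a more soluble compound, a lower number a less soluble compound), compound 1 gives 4000 nM and compound 2 gives 1600 nM. Among the measured compounds shown here, that pair forms the only measured step, a 2.5-fold lower number from compound 1 to compound 2 (0.40 log units; beyond the scatter), and it concerns hydrogen in place of bromo on an aromatic carbon. Compound 3 stands apart: in this assay it gives only < 1000 nM, which is a limit of the assay and not a number, as the limit of < 1000 nM in this assay, at which 1 of the 3 values shown sits, shows.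

Compound 4, `Cc1nc2c(c(-c3ccc4oc(N)nc4c3)nn2C(C)C)c(=O)[nH]1`, differs from compound 3 by methyl in place of methylamino on an aromatic carbon. For the measured compounds named here, no measured step concerns this kind of change, and the bromo-to-hydrogen step above sits on a different core, so it offers no direct guide. What remains is that compound 3 is already at the limit of this assay, and the change to compound 4 is small. Compound 4 is therefore expected to show roughly no step beyond the scatter, with a step that the limit leaves unreadable from compound 3 to compound 4 as the expected shift. The estimate for compound 4 in this assay is 800 nM, in a range from 250 nM to 2500 nM, with a real chance that only a limit is reported again.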

Compound 4, solubility: 3000 nM
For compound 4 the middle estimate is 3.8-fold (0.57 log units) below the measured one; the measured number lies above the stated range.
By their numbers in this assay, from the lowest: compounds 2, 4 and 1 (each within the scatter of the next, the first and the last beyond it). At a limit, below all of these: compound 3.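

In this assay the swap of methylamino for methyl gives an at least 3.0-fold higher number from compound 3 to compound 4 (0.47 log units; beyond the scatter) at this place between two ring nitrogen atoms, so the read-out does respond to a change here, one in which the leaving group has 1 hydrogen-bond donor and 1 hydrogen-bond acceptor and the entering group has 0 of each. Compound 3 gives < 1000 nM as a limit of the assay and not a number. The full size of the step stays unknown because its starting point is such a limit: the limit of < 1000 nM in this assay, at which 1 of the 4 values shown sits.

From the compounds shown here alone, whether an unsubstituted amine, a methoxy group or a longer chain such as propyl at this same place would give a number close to that of compound 4 stays open. Also open, going by these compounds, is whether methyl in place of methylamino would give a similar step on the core of compound 1.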